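The source may report more compounds than this note shows. Statements on the series, on what has been measured and on what is new or still open speak of the compounds shown alone.

Compound 1 `N/C(=N/NC(CC(=O)c1ccc(-n2ccnc2)cc1)c1ccccc1Cl)c1ccccn1` and compound 2 `N/C(=N/NC(CC(=O)c1ccc(-n2ccnc2)cc1)c1ccccc1Br)c1ccccn1` share one core; compound 2 differs by bromo in place of chloro on an aromatic carbon. In an ADME assay on Vero cells (Chlorocebus sabaeus) for cytotoxicity, read by MTT assay, with a stated time of 72 h (on this read-out lower numbers stand for higher toxicity in this test and higher numbers for lower toxicity in this test), compound 1 gives 53200 nM, and compound 2 gives 29000 nM, a step of a 1.8-fold lower number from compound 1 to compound 2 (0.26 log units; within the scatter). Compound 3 `N/C(=N/NC(CC(=O)c1ccc(-n2ccnc2)cc1)c1ccc(Cl)cc1)c1ccccn1` differs from compound 1 by 4-chlorophenyl in place of 2-chlorophenyl on a saturated chain carbon bound to an amine nitrogen and a saturated chain carbon; in this assay compound 3 gives 78800 nM, with a 1.5-fold higher number from compound 1 to compound 3 (0.17 log units; within the scatter) and a 2.7-fold higher number from compound 2 to compound 3 (0.43 log units; beyond the scatter). Compound 4 `N/C(=N/NC(CC(=O)c1ccc(-n2ccnc2)cc1)c1ccc(Br)cc1)c1ccccn1` has not been measured; it differs from compound 3 by bromo in place of chloro on an aromatic carbon. Within the data shown here, this is the same kind of change as the one made from compound 1 to compound 2, though the place differs: there the bromo sits ortho to a large group, here para to a large group. Because the earlier step of a 1.8-fold lower number from compound 1 to compound 2 (0.26 log units; within the scatter) stayed within the scatter, compound 4 is expected to show a step of about a 1.8-fold lower number from compound 3 to compound 4 (0.24 log units; within the scatter). Compound 4 is estimated at 45000 nM, between 20000 nM and 110000 nM.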

Compound 4, half-maximal cytotoxic concentration: 298000 nM
Compound 4: middle estimate off by 6.6-fold (0.82 log units), on the low side; measured number above the stated range.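

In this assay, the new step is a 3.8-fold higher number from compound 3 to compound 4 (0.58 log units; beyond the scatter) and bromo in place of chloro does not carry over as a fixed step from one core to the other in this series: the same change on two cores in this assay, a 1.8-fold lower number (0.26 log units; within the scatter) from compound 1 to compound 2 and a 3.8-fold higher number (0.58 log units; beyond the scatter) from compound 3 to compound 4, 6.9-fold (0.84 log units) apart, beyond the scatter of two such steps Compound 4 also stands well apart from the two compounds with the other aryl groups, with a 10-fold higher number from compound 2 to compound 4 (1.01 log units; beyond the scatter) and a 5.6-fold higher number from compound 1 to compound 4 (0.75 log units; beyond the scatter). This shows that the step seen on one core cannot be assumed on the other, but it rests on a single comparison of two steps and does not show why they differ or what the change would do on any further core.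

The compounds shown leave open whether fluoro, iodo or methyl in place of the halogen on the 4-substituted phenyl would give a number nearer that of compound 3 or compound 4.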